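From a Trifluoromethyl Anilide to a Trifluoromethoxy Anilide

The source may hold more compounds than are shown below. What is called first, only, known or untested is meant among the compounds shown, and "the series" means these compounds.

Measured compounds:
Compound 1 `Cc1ccc(C(=O)Nc2cccc(Cl)c2)cc1C#Cc1cc(-c2cnn(C)c2)cnc1N` — in an ADME assay on RBL-2H3 cells (Rattus norvegicus) for cytotoxicity, read by CCK-8 assay, with a stated time of 24 h (a higher number here means that more compound is tolerated, a lower number that less compound is tolerated), compound 1 gives 24.8 nM.
Compound 2 `Cc1ccc(C(=O)Nc2cccc(C(F)(F)F)c2)cc1C#Cc1cc(-c2cnn(C)c2)cnc1N` — in this assay compound 2 gives 7 nM.
Compound 3 `Cc1ccc(C(=O)Nc2ccc(C(F)(F)F)cc2)cc1C#Cc1cc(-c2cnn(C)c2)cnc1N` — in this assay compound 3 gives 14 nM.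

Compound 2 has the lowest number of the three; its nearest neighbour is compound 3, and the change a 2.0-fold higher number from compound 2 to compound 3 (0.30 log units; within the scatter) is within the scatter, whereas a 3.5-fold lower number from compound 1 to compound 2 (0.55 log units; beyond the scatter) lies beyond it. Compound 4 `Cc1ccc(C(=O)Nc2ccc(OC(F)(F)F)cc2)cc1C#Cc1cc(-c2cnn(C)c2)cnc1N` is not yet measured. Relative to compound 2 it carries 4-(trifluoromethoxy)phenyl in place of 3-(trifluoromethyl)phenyl on an amide-type nitrogen. Within the data shown here, the step that bears most directly on this move is a 2.0-fold higher number from compound 2 to compound 3 (0.30 log units; within the scatter), which compares the 3-(trifluoromethyl)phenyl and 4-(trifluoromethyl)phenyl anilides; no measured pair speaks to exchanging trifluoromethyl for trifluoromethoxy. In this assay compound 4 is therefore expected to sit close to compound 2, with a 1.7-fold higher number from compound 2 to compound 4 (0.23 log units; within the scatter) expected as a small upward drift or nothing beyond the scatter. Compound 4 is estimated at 12 nM, within 4 nM to 35 nM.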

Compound 4, half-maximal cytotoxic concentration: 41 nM
Beside the measured number, compound 4's estimate is 3.4-fold (0.53 log units) below it; the measured number lies above the stated range.
By their numbers in this assay, from the lowest: compounds 2, 3, 1 and 4 (each within the scatter of the next, the first and the last beyond it).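

In this assay, trifluoromethoxy in place of trifluoromethyl on an aromatic carbon gives a 2.9-fold higher number from compound 3 to compound 4 (0.47 log units; beyond the scatter) and shows that this exchange on the anilide can shift the number beyond the scatter. The wider change gives a 5.9-fold higher number from compound 2 to compound 4 (0.77 log units; beyond the scatter), while a 1.7-fold higher number from compound 1 to compound 4 (0.22 log units; within the scatter) leaves compound 4 within the scatter of the chloro anilide. Nothing measured here accounts for these steps.

Among these compounds, the exchange is seen only on the 4-(trifluoromethyl)phenyl anilide, so its effect on the 3-(trifluoromethyl)phenyl anilide remains open. Also open, as far as these compounds go, is how a methoxy group, a nitrile or a carboxylic acid would fare on this ring.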